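This account rests on a few compounds, and the source may have more. Where it says the series, first, only, none or still open, it means among the compounds named here.

In an assay on HeLa cells for inhibition of Indoleamine 2,3-dioxygenase 1 (Homo sapiens), with stated times of 1 h and 18 h (a lower number here means a stronger inhibitor, a higher number a weaker inhibitor), compound 1, `Cc1ccc(NC(=O)Nc2cc(-c3ccc(C(=O)O)cc3)ccc2Oc2ccccc2C(C)(C)C)cc1`, gives only a limit, > 1000 nM. Compound 2, `Cc1ccc(NC(=O)Nc2cc(-c3ccccc3C(=O)O)ccc2NC2CCCCC2)cc1`, gives 504 nM in this assay. Within the data shown here, compound 3, `Cc1ccc(NC(=O)Nc2cc(-c3ccccc3C(=O)O)ccc2N(C)C2CCCCC2)cc1`, gives 14 nM in this assay, the lowest number among the compounds measured, and the one step measured so far, a 36-fold lower number from compound 2 to compound 3 (1.56 log units; beyond the scatter), carries the whole of that difference. Compound 4, `Cc1ccc(NC(=O)Nc2cc(-c3ccccc3C(=O)O)ccc2N(CC(C)C)C(C)C)cc1`, has not yet been measured in this assay. It differs from compound 3 in one place: isobutyl(isopropyl)amino in place of cyclohexyl(methyl)amino on an aromatic carbon. Among the measured compounds shown here, the only measured step that bears on this spot is the one from compound 2 to compound 3, where a methyl took the place of a hydrogen on the nitrogen, and that step was large. For the measured compounds named here, compound 4 keeps a nitrogen that carries two carbon groups, as compound 3 does, so no step on that scale is expected here; a small shift, if any, is expected, a 2.1-fold higher number from compound 3 to compound 4 (0.33 log units; beyond the scatter). Compound 4 is therefore expected to give about 30 nM in this assay, with a range from 8 nM to 120 nM.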

Compound 4, half-maximal inhibitory concentration: 42 nM
Beside the measured number, compound 4's estimate is 1.4-fold (0.15 log units) below it; the measured number falls inside the stated range.
By their numbers in this assay, from the lowest: compound 3; then compound 4; then compound 2. At a limit, above all of these: compound 1.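

In this assay, the ring of the cyclohexyl(methyl)amino group is not essential: the open-chain isobutyl(isopropyl)amino group, with the same count of heavy atoms, costs only a modest step, a 3.0-fold higher number from compound 3 to compound 4 (0.48 log units; beyond the scatter). The earlier compounds shown here showed the gain from a second carbon group on this nitrogen in a single example, and a second example now shares it, a 12-fold lower number from compound 2 to compound 4 (1.08 log units; beyond the scatter). Among compound 2, compound 3 and compound 4, both nitrogens carrying two carbon groups therefore give lower numbers than the nitrogen carrying a hydrogen.

Nothing at hand explains either step, and opening the ring cannot be told apart from the change in the chains. A dimethylamino group or a piperidine ring at this position would show how much carbon the nitrogen needs and whether a ring that includes the nitrogen is tolerated.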